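A few compounds are considered here, and "the series" means these few. Any claim that something is new, unique, unknown or untested is made for them only; others in the source may bear on it.

Compound 2 `Cc1cccc(Oc2cccc(CN3CCC(n4cc(C)c(=O)[nH]c4=O)CC3)c2)c1` was tested in an ADME assay on MRC5 cells (Homo sapiens) for cytotoxicity, read by fluorescence and resazurin assay, with a stated time of 3 days; a higher number here means a weaker inhibitor, a lower number a stronger inhibitor. In this assay compound 2 stands only at the limit of the assay, > 64000 nM. Its close relative, compound 1 `Cc1ccc(Oc2cccc(CN3CCC(n4cc(C)c(=O)[nH]c4=O)CC3)c2)cc1`, sits at the same limit in this assay, > 64000 nM. The step that the two limits leave unreadable from compound 1 to compound 2 therefore cannot be read from the two limits. Compound 3 `Cc1cn(C2CCN(Cc3cccc(Oc4cc(C(F)(F)F)cc(C(F)(F)F)c4)c3)CC2)c(=O)[nH]c1=O` has no result in this assay: "not determined" (no result reported). The only firm point among the measured compounds is the limit of > 64000 nM in this assay, at which 2 of the 3 values shown sit.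

The new compound 4 `Cc1cn(C2CCN(Cc3cccc(OC4CCCCC4)c3)CC2)c(=O)[nH]c1=O` differs from compound 2 by cyclohexyl in place of 3-methylphenyl on an oxygen on an aromatic ring. No measured step bears on this change: the single step that exists is unreadable, and nothing among the shown compounds tells how a change of this kind moves the read-out. With both measured relatives at the limit, compound 4 is expected to land at a similar place, so the step that the limit leaves unreadable from compound 2 to compound 4 is estimated to be none beyond the scatter. The estimate for compound 4 in this assay is 80000 nM, with a range from 30000 nM to 200000 nM, and it is expected that the assay will most likely again report only a limit.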

Compound 4, half-maximal inhibitory concentration: 23600 nM
Compound 4: the middle estimate sits 3.4-fold (0.53 log units) above what was measured; the measured number lies below the stated range.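

In this assay, compound 4 is the first compound shown with a real number rather than a limit, so the group on this oxygen can move the read-out within the tested range. Swapping 3-methylphenyl for cyclohexyl gives an at least 2.7-fold lower number from compound 2 to compound 4 (0.43 log units; beyond the scatter), and swapping 4-methylphenyl for cyclohexyl gives an at least 2.7-fold lower number from compound 1 to compound 4 (0.43 log units; beyond the scatter). Both steps are only minimum sizes, since each starts from a limit and the true gaps may be larger: the limit of > 64000 nM in this assay, at which 2 of the 4 values shown sit.

The compounds shown leave open whether the change in the number follows from the loss of the aromatic ring or from something else about cyclohexyl. They also leave open how a smaller ring such as cyclopentyl, a straight butyl chain or a cyclohexyl carrying a hydroxyl group would read out here.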